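Ethyl to Cyclobutyl: Expected Effect on the Maximal Response

The source may report more compounds than this note shows. Statements on the series, on what has been measured and on what is new or still open speak of the compounds shown alone.

Of the compounds shown here, two have so far been measured in a functional assay on CHO cells for positive allosteric modulation of muscarinic acetylcholine receptor M5 (Homo sapiens), read by calcium flux; a higher number here means a larger maximal response, a lower number a smaller maximal response. Compound 1 `CCN(Cc1ccccc1)C(=O)C1CCN(S(=O)(=O)c2cccc(OC)c2)CC1` gives 77% in this assay. Compound 2 `CCCN(Cc1ccccc1C(F)(F)F)C(=O)C1CCN(S(=O)(=O)c2ccc3[nH]ncc3c2)CC1` gives 94% in this assay, the higher of the two numbers, and its gap to compound 1 lies beyond the usual scatter of repeated measurements. Compound 3 `O=C(C1CCN(S(=O)(=O)c2ccc3[nH]ncc3c2)CC1)N(Cc1ccccc1C(F)(F)F)CC1CCC1` has not yet been measured. It differs from compound 2 in one place: cyclobutyl in place of ethyl on a saturated chain carbon bound to an amide-type nitrogen. Neither the leaving nor the entering group carries a hydrogen-bond donor, an acceptor or a charge, so the change stays within a saturated carbon group. Among the compounds with values here, no measured pair shows what such a change does in this assay, so the expectation rests on compound 2 alone. The expected step, a number 2 percentage points lower from compound 2 to compound 3 (within the scatter), is small and lies within the usual scatter. For compound 3 the expected value in this assay is 92%, with a range from 78% to 100%.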

Compound 3, largest response reached (reported as percent of maximum), in percent of the reference or control that the assay uses: 103%
The estimate for compound 3 lay 11 percentage points below the measured number; measured number above the stated range.
By their numbers in this assay, from the lowest: compound 1; then compounds 2 and 3 (each within the scatter of the next).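

In this assay the swap of ethyl for cyclobutyl on a saturated chain carbon bound to an amide-type nitrogen gives a number 9 percentage points higher from compound 2 to compound 3 (within the scatter) and so leaves the maximal response within the scatter. This first pair differing in one place shows that the position takes cyclobutyl, with 4 heavy atoms against 2 for ethyl and a four-membered ring, without a step beyond the scatter. No measurement at hand explains this result.

From the compounds shown here alone, whether a longer chain such as butyl, a larger ring such as cyclohexyl, or an amine at this place would also hold the response stays open. One pair also cannot say whether the same change would read alike on compound 1, which carries ethyl at this place on a different core.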